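This account rests on a few compounds, and the source may have more. Where it says the series, first, only, none or still open, it means among the compounds named here.

Measured so far:
compound 1, `C=CC(=O)Nc1cc(C(F)(F)F)cc(C(F)(F)F)c1`, 5.5 h
compound 2, `C=CC(=O)Oc1cc(C(F)(F)F)cc(C(F)(F)F)c1`, < 0.017 h

In an ADME assay for pharmacokinetics, read by LC-MS, in phosphate buffer, with a stated time of 72 h, at pH 7.4, tested at 250 uM (a higher number here means that the compound lasts longer, a lower number that the compound disappears faster), compound 1 gives 5.5 h. For compound 2 the value in this assay is only a limit, < 0.017 h, and the limit of < 0.017 h in this assay, at which 1 of the 2 values shown sits, marks it as such. Within the data shown here, compound 2 therefore stands at the short end of the two numbers seen: the single measured step, an at least 320-fold lower number from compound 1 to compound 2 (2.50 log units; beyond the scatter), is the only comparison on record, and it shows that exchanging the (vinylcarbonyl)amino group of compound 1 for the (vinylcarbonyl)oxy group of compound 2 on an aromatic carbon shortened the half-life beyond the scatter.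

Compound 3, `C=CS(=O)(=O)c1cc(C(F)(F)F)cc(C(F)(F)F)c1`, has not been measured. It differs from compound 2 in one place: vinylsulfonyl in place of (vinylcarbonyl)oxy on an aromatic carbon, on an aromatic carbon that is meta to two trifluoromethyl groups. Among the measured compounds shown here, the step that bears on this change is the one from compound 1 to compound 2, since it removed the (vinylcarbonyl)oxy group that compound 3 also lacks, and it was large. Compound 3 is therefore expected to show a large step upward in this assay, an at least 1700-fold higher number from compound 2 to compound 3 (3.24 log units; beyond the scatter), and its half-life is estimated at 30 h, within 3 h to 300 h.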

Compound 3, half-life: < 0.017 h
Compound 3 was reported as a limit; the forecaster's own chance of this, stated with the estimate: 40%; middle value at least 1700-fold (3.24 log units) away from the limit.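

In this assay compound 3 gives < 0.017 h, which is a limit of the assay and not a number. Among these compounds, with vinylsulfonyl in place of (vinylcarbonyl)amino on this aromatic carbon, meta to two trifluoromethyl groups, the result is an at least 320-fold lower number from compound 1 to compound 3 (2.50 log units; beyond the scatter), so (vinylcarbonyl)oxy is no longer the only group here that falls far short of the half-life of compound 1. Compound 2 and compound 3 now share the same limit, so the step between them cannot be read and the vinylsulfonyl and (vinylcarbonyl)oxy groups cannot be placed in any order: the limit of < 0.017 h in this assay, at which 2 of the 3 values shown sit.

As far as these compounds go, how far the true half-lives of compound 2 and compound 3 lie past that limit remains open, and a shorter time scale would be needed to tell them apart. From the compounds shown here alone, it also remains open whether the half-life of compound 1 would hold with another nitrogen-linked group at this position, such as a propanoylamino group, which has a saturated chain in place of the vinyl, or whether it depends on the (vinylcarbonyl)amino group as it stands.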